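Propyl chain carbamate extension in the benzimidazole amide series

A few compounds are considered here, and "the series" means these few. Any claim that something is new, unique, unknown or untested is made for them only; others in the source may bear on it.

Working notes on the series. In an assay for activation of interferon regulatory factor 3 (Homo sapiens), read by a luciferase reporter, with a stated time of 20 h (on this read-out lower numbers stand for an effect already at smaller amounts and higher numbers for an effect only at larger amounts of compound), compound 2 `CCCn1c(NC(=O)c2ccc3ccccc3n2)nc2cc(C(N)=O)cc(OC)c21` gives > 100000 nM, which is a limit of the assay rather than a number. Compound 3 `CCCn1c(NC(=O)c2cccnn2)nc2cc(C(N)=O)cc(OC)c21` reads > 100000 nM in this assay, likewise a limit. Compound 1 `CCn1nc(C)cc1C(=O)Nc1nc2cc(C(N)=O)cc(OC)c2n1CCCNC(=O)OCc1ccccc1` also sits at > 100000 nM in this assay, again a limit. The step from compound 2 to compound 3 is a step that the two limits leave unreadable from compound 2 to compound 3, so it tells nothing about size or direction. Compound 4 `COc1cc(C(N)=O)cc2nc(NC(=O)c3ccc4ccccc4n3)n(CCCNC(=O)OCc3ccccc3)c12` differs from compound 2 by (benzyloxycarbonyl)amino in place of hydrogen on a saturated chain carbon, three bonds along the chain from an aromatic nitrogen. Compound 1 carries the same chain with the (benzyloxycarbonyl)amino group and a different acyl piece, and all three measured values stand at the limit of > 100000 nM in this assay, at which 3 of the 3 values shown sit, so no measured step can be read against this change. The expected step from compound 2 to compound 4 is a step that the limit leaves unreadable from compound 2 to compound 4, with no direction favoured beyond scatter, and compound 4 is most likely to return only a limit. Compound 4 is estimated at 150000 nM, ranging from 30000 nM to 1000000 nM.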

Compound 4, half-maximal effective concentration: > 100000 nM
Compound 4 ended at the assay's limit; the forecaster's own chance of this, stated with the estimate: 80%; the middle value is on the limit's open side.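

Within the data shown here, compound 4 gives no new readable step against compound 2 or compound 1 in this assay, and each value is a limit of the assay rather than a number: the limit of > 100000 nM in this assay, at which 4 of the 4 values shown sit. The compounds shown leave open whether any change on the shared core gives a measurable value in this assay.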